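The source may hold more compounds than are shown below. What is called first, only, known or untested is meant among the compounds shown, and "the series" means these compounds.

Measured so far:
- compound 1, `COc1cccc(NC(=S)N/N=C/c2ccc3ccccc3n2)c1`: 74500 nM
- compound 2, `Cc1csc2sc(/C=N/NC(N)=S)c(C)c12`: 1120 nM
- compound 3, `CC(C)c1cccc(C(C)C)c1NC(=S)N/N=C/c1ccc2ccccc2n1`: 16400 nM

In a functional assay on HeLa cells (Homo sapiens) for antiproliferative activity, read by sulforhodamine B assay, with a stated time of 72 h (a lower number here means a stronger inhibitor, a higher number a weaker inhibitor), compound 1 gives the highest number of the three, so it is the weakest inhibitor shown. Its nearest neighbour is compound 3, which gives 16400 nM, a gap beyond the scatter; compound 2, with 1120 nM, lies furthest away.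

Compound 4, `S=C(N/N=C/c1ccc2ccccc2n1)Nc1cccc(Br)c1`, has not yet been measured in this assay. It differs from compound 1 in one place: bromo in place of methoxy on an aromatic carbon. Among the measured compounds shown here, no step between measured compounds matches this change, so the expectation rests only on the spread of the three numbers. A moderate move toward a lower number, beyond the scatter, is expected for compound 4, with a step of a 3.0-fold lower number from compound 1 to compound 4 (0.47 log units; beyond the scatter). The estimate for compound 4 is 25000 nM, within a range of 6000 nM to 90000 nM.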

Compound 4, half-maximal inhibitory concentration: 70000 nM
Beside the measured number, compound 4's estimate is 2.8-fold (0.45 log units) below it; the range from low to high includes it.
By their numbers in this assay, from the lowest: compound 2; then compound 3; then compounds 4 and 1 (each within the scatter of the next).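

In this assay, the exchange of 3-methoxyphenyl for 3-bromophenyl gives a 1.1-fold lower number from compound 1 to compound 4 (0.03 log units; within the scatter), so the two compounds cannot be told apart. At this place on the ring, then, the methoxy and its oxygen, a hydrogen-bond acceptor, can give way to a single bromine with no readable effect on the number. Nothing measured here accounts for this outcome.

As far as these compounds go, whether an amine or a carboxylic acid at the same place would also leave the number unmoved remains open. So does whether the same exchange would behave alike on another core.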